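Notes on a benzothiazole-imine series: chain change at compound 4

The source may report more compounds than this note shows. Statements on the series, on what has been measured and on what is new or still open speak of the compounds shown alone.

Measured so far:
- Compound 1, `CCCc1ccc2nc(N)sc2c1`: in a functional assay on the whole organism with Rattus norvegicus as the target (on this read-out higher numbers stand for an effect only at larger amounts of compound and lower numbers for an effect already at smaller amounts), compound 1 gives 6 mg/kg.
- Compound 2, `N=c1sc2cc(OC(F)(F)F)ccc2n1CCS(=O)(=O)O`: in this assay compound 2 gives > 10 mg/kg, which is a limit of the assay and not a number.
- Compound 3, `N=c1sc2cc(OC(F)(F)F)ccc2n1CCN1CCN(c2ccccc2)CC1`: in this assay compound 3 gives 3.5 mg/kg.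

Compound 2 therefore stands only at the limit of > 10 mg/kg in this assay, at which 1 of the 3 values shown sits; no number for it is known, so its distance to compound 1 or compound 3 cannot be stated. No pair of these compounds differs in a single place, so no measured step is available.

Compound 4, `CC[S+]([O-])CCn1c(=N)sc2cc(OC(F)(F)F)ccc21`, is not yet measured. It differs from compound 2 as follows: a group of 4 heavy atoms (2 carbon, 1 oxygen, 1 sulfur; no ring) in place of a group of 4 heavy atoms (3 oxygen, 1 sulfur; no ring), on a saturated chain carbon, two bonds along the chain from an aromatic nitrogen. The entering group has 0 hydrogen-bond donors and 1 hydrogen-bond acceptor where the sulfo group had 1 hydrogen-bond donor and 2 hydrogen-bond acceptors.

Compound 3 shares the core of compound 2. In this assay compound 3 gives a number, 3.5 mg/kg, as does compound 1 with 6 mg/kg. On that basis compound 4 is expected to return a number rather than a limit, with the step of an at least 2.0-fold lower number from compound 2 to compound 4 (0.30 log units; that floor lies within the scatter) expected to run toward smaller amounts. For compound 4 the estimate is 5 mg/kg, within a range from 2 mg/kg to 15 mg/kg.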

Compound 4, dose for half-maximal effect: 1.2 mg/kg
Compound 4: the middle estimate sits 4.2-fold (0.62 log units) above what was measured, and the stated range ends above it.
By their numbers in this assay, from the lowest: compound 4; then compounds 3 and 1 (each within the scatter of the next). At a limit, above all of these: compound 2.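

In this assay the saturated chain carbon two bonds along the chain from an aromatic nitrogen proves to be a place where the end group counts: the sulfo group gives way to a group of 4 heavy atoms (2 carbon, 1 oxygen, 1 sulfur; no ring), with an at least 8.3-fold lower number from compound 2 to compound 4 (0.92 log units; beyond the scatter) as the result of that single change. For the compounds shown here, this is the first step between two compounds that differ in one place, and it lies beyond the scatter, so the chain end can now be treated as a point where the read-out moves on the shared core. The printed size is only a floor because compound 2 stands at a limit of the assay and not at a number: the limit of > 10 mg/kg in this assay, at which 1 of the 4 values shown sits.

Open, from the compounds shown here alone, is whether the step comes from losing the sulfo group or from the particular sulfur-bearing group that enters, which a carboxylic acid, an amine or a longer chain at the same place would help to separate. Going by these compounds, the full size of the step also stays open, as compound 2 has no number to measure it from.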